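Changing One Amide Partner on Compound 2

This account rests on a few compounds, and the source may have more. Where it says the series, first, only, none or still open, it means among the compounds named here.

Within the data shown here, in a physicochemical assay for solubility, read by nephelometry, measured as kinetic solubility, at pH 6.5 (a lower number here means a less soluble compound, a higher number a more soluble compound), compound 2 `CC(C)(C)c1cc(C(=O)Nc2cccc(CN)c2)n(Cc2ccccc2)n1` gives 25 ug/mL, the only exact number so far. Compound 1 `NCc1csc(NC(=O)c2ccccn2)n1` reads > 100 ug/mL, which is a limit of the assay and not a number. Compound 3 `CN(C)Cc1csc(NC(=O)c2cc(C(C)(C)C)nn2Cc2ccccc2)n1` carries 4-((dimethylamino)methyl)-1,3-thiazol-2-yl in place of 3-(aminomethyl)phenyl on an amide-type nitrogen. Among the measured compounds shown here, no measured pair shows this change, so the expected step of a 1.2-fold higher number from compound 2 to compound 3 (0.08 log units; within the scatter) in this assay is slightly upward and stays within the usual scatter. For compound 3 the estimated solubility is 30 ug/mL, with an expected range between 10 ug/mL and 90 ug/mL.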

Compound 3, solubility: 25 ug/mL
Beside the measured number, compound 3's estimate is 1.2-fold (0.08 log units) above it; low and high end bracket the measured number.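

Among these compounds, replacing 3-(aminomethyl)phenyl with 4-((dimethylamino)methyl)-1,3-thiazol-2-yl on the amide-type nitrogen gives the first readable step in this assay, which shows no change at the digits printed from compound 2 to compound 3 (within the scatter). In this one pair, a six-membered aromatic ring of carbon only and a five-membered aromatic ring with 2 hetero atoms read alike. Compound 1 holds a limit of the assay and not a number, so it adds no step: the limit of > 100 ug/mL in this assay, at which 1 of the 3 values shown sits.

The ring and its amine end change together here, so their separate contributions cannot be read. On these data alone, how a carboxylic acid or a morpholine at this position would read also stays open.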